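Methyl for Cyano in a Pyrazole Amide Series

The compounds below may be only part of what the source reports. "The series", "measured", "known", "first", "only" and "open" are said of these compounds alone.

compound 1: `COc1cccc([C@@H](C)NC(=O)c2ccc(-c3cn[nH]c3)c(C#N)c2)c1` — 6.7 nM
compound 2: `COc1cc(C(=O)N[C@H](C)c2ccccc2F)ccc1-c1cn[nH]c1` — 1.3 nM
compound 3: `COc1cc(NC(=O)[C@H](N)CCc2ccccc2)ccc1-c1cn[nH]c1` — 5.6 nM

In an assay on isolated protein for inhibition of Rho-associated protein kinase 2 (Homo sapiens), read by mobility shift assay (on this read-out lower numbers stand for stronger inhibition and higher numbers for weaker inhibition), compound 1 gives 6.7 nM, the highest number of the three. Compound 3 lies nearest with 5.6 nM, a gap within the scatter. Compound 2 with 1.3 nM sits beyond the scatter with a lower number.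

Compound 4 `COc1cccc([C@@H](C)NC(=O)c2ccc(-c3cn[nH]c3)c(C)c2)c1` is not yet measured. It differs from compound 1 in one place: methyl in place of cyano on an aromatic carbon. Among the compounds with values here, no measured pair shows this change, so there is no step to lean on. The step is expected to be small, leaning if anything toward a higher number, a 1.8-fold higher number from compound 1 to compound 4 (0.25 log units; within the scatter). Compound 4 is accordingly estimated at 12 nM, with a range from 4 nM to 40 nM.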

Compound 4, half-maximal inhibitory concentration: 1 nM
The estimate for compound 4 lay 12-fold (1.08 log units) above the measured number, and the stated range ends above it.
By their numbers in this assay, from the lowest: compounds 4 and 2 (each within the scatter of the next); then compounds 3 and 1 (each within the scatter of the next).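

In this assay, the aromatic carbon ortho to the 1H-pyrazol-4-yl group gives the series its first one-place step: methyl in place of cyano brings a 6.7-fold lower number from compound 1 to compound 4 (0.83 log units; beyond the scatter), beyond the scatter. On this pair, the nitrile and its hydrogen-bond acceptor are not required for a low number at this position. No measurement at hand explains the step.

One pair cannot show whether the step carries over to other amide side chains. Also open, going by these compounds, is how a chlorine or a longer chain such as ethyl would read at this position.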